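This account rests on a few compounds, and the source may have more. Where it says the series, first, only, none or still open, it means among the compounds named here.

In an ADME assay on microsomes from liver (Mus musculus) for metabolic stability, with a stated time of 10 min (on this read-out lower numbers stand for a less stable compound and higher numbers for a more stable compound), the three measured compounds give:

- compound 1, `C[C@]1(C(=O)O)CC[C@H](C(=O)N2CC[C@](c3ccc(C(F)(C(F)(F)F)C(F)(F)F)cc3)(S(=O)(=O)c3ccc(F)cc3)C2)CC1`: 93%
- compound 2, `C[C@]1(C(=O)N2CC[C@](c3ccc(C(F)(C(F)(F)F)C(F)(F)F)cc3)(S(=O)(=O)c3ccc(F)cc3)C2)CC[C@@H](C(=O)O)CC1`: 100%
- compound 3, `O=C(O)C12CCC(C(=O)N3CC[C@](c4ccc(C(F)(C(F)(F)F)C(F)(F)F)cc4)(S(=O)(=O)c4ccc(F)cc4)C3)(CC1)CC2`: 73%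

Compound 3 stands lowest of the three, with a number 20 percentage points lower from compound 1 to compound 3 (beyond the scatter) and a number 27 percentage points lower from compound 2 to compound 3 (beyond the scatter) both going beyond the scatter, while a number 7 percentage points higher from compound 1 to compound 2 (within the scatter) stays within it. Compound 4, `CCC1(C(=O)N2CC[C@](c3ccc(C(F)(C(F)(F)F)C(F)(F)F)cc3)(S(=O)(=O)c3ccc(F)cc3)C2)CCS(=O)(=O)CC1`, differs from compound 3 in one place: a group of 10 heavy atoms (7 carbon, 2 oxygen, 1 sulfur; one six-membered non-aromatic ring with 1 hetero atom) in place of a group of 11 heavy atoms (9 carbon, 2 oxygen; 2 six-membered non-aromatic rings of carbon only), on a carbonyl carbon. Among the compounds with values here, no measured step covers the group that enters here; the two steps into compound 3 only concern the group that now leaves, and both were modest and downward. The expected step in this assay is therefore uncertain, with a small rise as the most likely outcome: a number 5 percentage points higher from compound 3 to compound 4 (within the scatter). Compound 4 is estimated at 78%, between 45% and 100%.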

Compound 4, percent of the compound remaining: 0%
Compound 4: middle estimate off by 78 percentage points, on the high side; the whole stated range lies above it.
By their numbers in this assay, from the lowest: compound 4; then compound 3; then compounds 1 and 2 (each within the scatter of the next).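

With only the group on this carbonyl carbon changed, the read-out in this assay can collapse: the series shows a number 73 percentage points lower from compound 3 to compound 4 (beyond the scatter) and a number 100 percentage points lower from compound 2 to compound 4 (beyond the scatter) as well as a number 93 percentage points lower from compound 1 to compound 4 (beyond the scatter) in the same setting. Within the data shown here, the earlier carboxy-bearing groups therefore did not show how much this position can matter, and 4-ethyl-1,1-dioxothian-4-yl is the first group here with 0 hydrogen-bond donors. No measured evidence explains the loss. Going by these compounds, the ring, the ethyl chain and the absent carboxy group all change at once, so which of them matters stays open. An amine on the same ring could help separate them.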